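Benzyl in place of pyrimidin-2-yl on an amine nitrogen

The source may hold more compounds than are shown below. What is called first, only, known or untested is meant among the compounds shown, and "the series" means these compounds.

In an in vitro ADME assay on microsomes from liver (Homo sapiens) for pharmacokinetics, read by LC-MS, with a stated time of 10 min, tested at 1 uM (on this read-out higher numbers stand for fast clearance and lower numbers for slow clearance), compound 2 (`Nc1ccccc1NC(=O)/C=C/c1ccc([C@H]2CN(c3ncccn3)C[C@@H]2C(=O)Nc2ccc(Cl)cc2)cc1`) gives 11 mL/min/kg and compound 1 (`Nc1ccccc1NC(=O)/C=C/c1ccc([C@H]2CN(C3COC3)C[C@@H]2C(=O)Nc2ccc(Cl)cc2)cc1`) gives 13 mL/min/kg so the two stand within the scatter of each other. Among the measured compounds shown here, compound 3 (`Nc1ccccc1NC(=O)/C=C/c1ccc([C@H]2CN(Cc3ccccc3)C[C@@H]2C(=O)Nc2ccc(Cl)cc2)cc1`) carries benzyl in place of pyrimidin-2-yl on an amine nitrogen in a ring and no benzyl compound has yet been measured. For the measured compounds named here, one measured step bears on this nitrogen (a 1.2-fold lower number from compound 1 to compound 2 (0.07 log units; within the scatter)) and it stayed within the scatter, so no step beyond the scatter is expected. The estimated step (a 1.4-fold higher number from compound 2 to compound 3 (0.13 log units; within the scatter)) is small and its direction remains uncertain. The expected value for compound 3 is 15 mL/min/kg with an estimated range from 8 mL/min/kg to 28 mL/min/kg in this read-out.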

Compound 3, clearance: 3 mL/min/kg
Compound 3: middle estimate off by 5.0-fold (0.70 log units), on the high side, outside the stated range (below it).
By their numbers in this assay, from the lowest: compound 3; then compounds 2 and 1 (each within the scatter of the next).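

In this assay, among the compounds shown here, the group on this ring nitrogen moved clearance beyond the scatter for the first time, with benzyl giving a 3.7-fold lower number from compound 2 to compound 3 (0.56 log units; beyond the scatter) and a 4.3-fold lower number from compound 1 to compound 3 (0.64 log units; beyond the scatter). Pyrimidin-2-yl and oxetan-3-yl had stayed within the scatter of each other, so benzyl alone sets compound 3 apart among these three groups. No measurement at hand explains this difference.

Going by these compounds, whether the lower number belongs to the phenyl ring or to its methylene link stays open, and a phenyl directly on this nitrogen or a longer phenethyl chain would bear on that. On these data alone, it is also open whether a pyridylmethyl group would keep the number this low.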